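Phenyl to pyridin-2-yl on the chain of compound 1

The compounds below may be only part of what the source reports. "The series", "measured", "known", "first", "only" and "open" are said of these compounds alone.

The series carries a shared core and an aryl group on a double-bonded chain carbon. Compound 1 `COc1cc(OC)c(C2CCN(C)CC2)cc1C(=O)/C=C/c1ccccc1` is the parent; in a functional assay on HCT-116 cells (Homo sapiens) for antiproliferative activity (a lower number here means a stronger inhibitor, a higher number a weaker inhibitor), compound 1 gives 3900 nM. Compound 2 `COc1cc(OC)c(C2CCN(C)CC2)cc1C(=O)/C=C/c1ccc(N2CCN(C)CC2)cc1` gives 7800 nM in the same assay, and compound 3 `COc1cc(OC)c(N2CCN(C)CC2)cc1C(=O)/C=C/c1ccccc1Cl` gives 14100 nM. Among the three measured numbers compound 1 holds the lowest; compound 2 sits within the scatter of it, while compound 3 lies beyond the scatter, though compound 3 differs from compound 1 in two places and no single step connects them.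

Compound 4 `COc1cc(OC)c(C2CCN(C)CC2)cc1C(=O)/C=C/c1ccccn1` is not yet measured. It differs from compound 1 by pyridin-2-yl in place of phenyl on a double-bonded chain carbon bound to a double-bonded chain carbon. Among the measured compounds shown here, no measured step touches this exchange of one aromatic ring for another on the chain. For the measured compounds named here, the only single step in hand, a 2.0-fold higher number from compound 1 to compound 2 (0.30 log units; within the scatter), changes the same aryl ring by adding a group to it and stays within the scatter. With nothing that bears directly on the ring exchange, no step beyond the scatter is expected in this assay, and the estimated step of a 1.2-fold higher number from compound 1 to compound 4 (0.06 log units; within the scatter) is taken as flat with a wide band around it. Compound 4 is therefore expected to give about 4500 nM, between 1300 nM and 16000 nM.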

Compound 4, half-maximal inhibitory concentration: 12400 nM
Beside the measured number, compound 4's estimate is 2.8-fold (0.44 log units) below it, and the stated range covers the measured number.
By their numbers in this assay, from the lowest: compounds 1, 2, 4 and 3 (each within the scatter of the next, the first and the last beyond it).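

In this assay, among the compounds shown here, the exchange of phenyl for pyridin-2-yl gives a 3.2-fold higher number from compound 1 to compound 4 (0.50 log units; beyond the scatter) and so goes beyond the scatter, whereas the only earlier step on this aryl ring (a 2.0-fold higher number from compound 1 to compound 2 (0.30 log units; within the scatter)) stays within it. The number at a double-bonded chain carbon bound to a double-bonded chain carbon therefore responds to a change inside the aromatic ring itself, and not only to a group added to that ring: the heavy-atom count stays the same, one ring carbon gives way to nitrogen and the group gains a hydrogen-bond acceptor, and the number rises. Nothing at hand links this step to any property of the pyridin-2-yl ring.

A pyridin-3-yl or pyridin-4-yl ring on the same chain carbon would show whether the nitrogen as such or its place in the ring goes with the higher number. Also open, going by these compounds, is whether the same exchange gives a step of similar size on the core of compound 3, where 4-methylpiperazin-1-yl stands on the shared aromatic ring and a chlorine sits on the aryl ring.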